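Compound 1 loses its drawn configuration

This account rests on a few compounds, and the source may have more. Where it says the series, first, only, none or still open, it means among the compounds named here.

Compound 1 `CC[C@@H](/N=C(\S)NCc1ccc(C(C)(C)C)cc1)c1ccc(NS(C)(=O)=O)cc1`: 50 nM
Compound 2 `C[C@@H](/N=C(\S)NCc1ccc(C(C)(C)C)cc1)c1ccc([N+](=O)[O-])cc1`: 580 nM

In a functional assay for inhibition, with Rattus norvegicus as the target (a higher number here means a weaker inhibitor, a lower number a stronger inhibitor), compound 1 holds the lower of the two numbers (50 nM), well clear of compound 2 (580 nM). The gap between the two lies beyond the scatter. Compound 3 `CCC(/N=C(\S)NCc1ccc(C(C)(C)C)cc1)c1ccc(NS(C)(=O)=O)cc1` changes one thing: the two compounds have the same atoms and bonds; at least one stereo element is drawn with a configuration in one of them and without one in the other: 1 of 2 stereo elements differ; a stereocentre at a saturated chain carbon is drawn R in compound 1 and without a configuration in compound 3 and a stereocentre at a saturated chain carbon is drawn R in compound 1 and without a configuration in compound 3. Going by the values given here, no measured pair shows such a change. With atoms and bonds the same, a small rise from compound 1 at 50 nM is expected, about the size of the scatter. The estimated move is a 1.8-fold higher number from compound 1 to compound 3 (0.26 log units; within the scatter) in this direction. For compound 3 the expected value is 90 nM within an estimated range from 40 nM to 200 nM as the likely span.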

Compound 3, half-maximal inhibitory concentration: 360 nM
Estimate against measurement, compound 3: 4.0-fold (0.60 log units) below; measured number above the stated range.
By their numbers in this assay, from the lowest: compound 1; then compounds 3 and 2 (each within the scatter of the next).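

At the stereocentre at a saturated chain carbon, dropping the drawn R configuration while atoms and bonds stay the same gives, in this assay, a 7.2-fold higher number from compound 1 to compound 3 (0.86 log units; beyond the scatter). Compound 1 and compound 2 could not show this, as they differ in more than one place. Here the step follows a single difference, so the way this one centre is drawn goes with a real change in the number: the fact that one of compounds 1 and 3 is drawn with a defined configuration and the other without, at the place where they differ

The compounds shown leave open where a drawn S configuration at this centre would stand. They also leave open whether the same step would appear with a propyl chain on the stereocentre.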